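The source may hold more compounds than are shown below. What is called first, only, known or untested is meant among the compounds shown, and "the series" means these compounds.

Three compounds share one core and have been tested in a functional assay on A375P cells (Homo sapiens) for antiproliferative activity, read by MTT assay, with a stated time of 48 h; a higher number here means a weaker inhibitor, a lower number a stronger inhibitor:

Compound 1, `Nc1cccc2c(-c3cccc(NC(=O)c4ccc(Cl)c(C(F)(F)F)c4)c3)ccnc12`, gives 1400 nM.
Compound 2, `CC(=O)Nc1cccc2c(-c3cccc(NC(=O)c4ccc(Br)c(C)c4)c3)ccnc12`, reaches only a limit of the assay, > 20000 nM.
Compound 3, `CC(=O)Nc1cccc2c(-c3cccc(NC(=O)c4ccc(Cl)c(C(F)(F)F)c4)c3)ccnc12`, gives 2400 nM.

Compound 3 carries the highest of the two actual numbers, but its nearest neighbour is compound 1, and a 1.7-fold higher number from compound 1 to compound 3 (0.23 log units; within the scatter), so the two cannot be told apart. Compound 2 stands apart as a limit rather than a number, (the limit of > 20000 nM in this assay, at which 1 of the 3 values shown sits).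

Compound 4, `CC(=O)Nc1cccc2c(-c3cccc(NC(=O)c4ccc5c(c4)OCCO5)c3)ccnc12`, is compound 3 with a single change: 2,3-dihydro-1,4-benzodioxin-6-yl in place of 4-chloro-3-(trifluoromethyl)phenyl on a carbonyl carbon. Going by the values given here, only one measured step touches this same place, namely an at least 8.3-fold lower number from compound 2 to compound 3 (0.92 log units; beyond the scatter). That step shows that swapping the group on the carbonyl carbon can shift the number a long way, and that of the two groups tried so far the 4-chloro-3-(trifluoromethyl)phenyl gave the stronger compound. Among the compounds with values here, the incoming 2,3-dihydro-1,4-benzodioxin-6-yl resembles neither group, so the direction is uncertain, but the one comparison available points to weaker activity when that group is removed. Compound 4 is therefore expected to give 12000 nM, with a range from 3000 nM to 40000 nM, which would mean a 5.0-fold higher number from compound 3 to compound 4 (0.70 log units; beyond the scatter), and a fair chance that only a limit is reported.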

Compound 4, half-maximal inhibitory concentration: 570 nM
For compound 4 the middle estimate is 21-fold (1.32 log units) above the measured one, and the stated range ends above it.
By their numbers in this assay, from the lowest: compound 4; then compounds 1 and 3 (each within the scatter of the next). At a limit, above all of these: compound 2.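

Going by these compounds alone, the earlier compounds showed only that one substituted phenyl group could do better than another on this carbonyl carbon, and a group with no halogen now does better than both in this assay, with a 4.2-fold lower number from compound 3 to compound 4 (0.62 log units; beyond the scatter). The 2,3-dihydro-1,4-benzodioxin-6-yl therefore ranks first of the three groups tried here on the acetylated core, and the full span at this place is an at least 35-fold lower number from compound 2 to compound 4 (1.54 log units; beyond the scatter). That span has an open end, since the value of compound 2 is a limit and not a number: the limit of > 20000 nM in this assay, at which 1 of the 4 values shown sits.

The entering group differs from the leaving one in several ways at once, bringing a non-aromatic ring and 2 hydrogen-bond acceptors while losing the chlorine and the trifluoromethyl, so the compounds shown cannot say which of these differences matters; a plain phenyl or a phenyl carrying methoxy groups on this carbonyl carbon would help to separate them. As far as these compounds go, it also remains open whether the 2,3-dihydro-1,4-benzodioxin-6-yl keeps its advantage on the free amine of compound 1, where the acetyl is replaced by hydrogen.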